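A few compounds are considered here, and "the series" means these few. Any claim that something is new, unique, unknown or untested is made for them only; others in the source may bear on it.

Measured so far:
- compound 1 `CC1=C(C(=O)OC(C)C)[C@H](c2ccco2)NC(=S)N1` — 10%
- compound 2 `CC1=C(C(=O)OC(C)(C)C)C(c2ccco2)NC(=S)N1` — 3%
- compound 3 `CC1=C(C(=O)OCc2ccccc2)C(c2ccco2)NC(=S)N1` — 32%

In an assay on membranes from CHO cells for displacement of a labelled ligand from adenosine receptor A1 (Homo sapiens), read by scintillation counting, with a stated time of 60 min, tested at 1 uM (on this read-out higher numbers stand for more inhibition at the one concentration tested (going by the name of the read-out) and lower numbers for less inhibition), compound 3 gives 32%, the highest of the three numbers. Compound 1 gives 10%, which is beyond the scatter below compound 3, and compound 2 gives 3%, also beyond the scatter below compound 3. Among the compounds with values here, the only step between two compounds that differ in one place is the change of the ester group: a number 29 percentage points higher from compound 2 to compound 3 (beyond the scatter), a modest gain. Compound 1 and compound 3 differ at the same ester group, and their two values point the same way.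

Compound 4 `CC1=C(C(=O)OCc2ccccc2)C(c2ccoc2)NC(=S)N1` differs from compound 3 by furan-3-yl in place of furan-2-yl on a saturated ring carbon. Within the data shown here, no measured step touches this position; the one known step concerns the ester group and says nothing about the furan. The expectation therefore rests on the value of compound 3 alone, and a step of a number 4 percentage points lower from compound 3 to compound 4 (within the scatter) is expected, which means no change beyond the scatter, with a wide band of uncertainty. Compound 4 is estimated at 28%, in a range from 8% to 50%.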

Compound 4, a percentage reported as inhibition, at one concentration (the size of the read-out at that concentration, not a potency): 25%
The estimate for compound 4 lay 3 percentage points above the measured number; the measured number falls inside the stated range.
By their numbers in this assay, from the lowest: compounds 2 and 1 (each within the scatter of the next); then compounds 4 and 3 (each within the scatter of the next).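

In this assay, moving the point of attachment of the furan gives a number 7 percentage points lower from compound 3 to compound 4 (within the scatter), so furan-3-yl and furan-2-yl are not told apart on this saturated ring carbon when the benzyl ester is present. Within the data shown here, this is the first reading at this position, as the earlier step concerned only the ester group, and it shows that this exchange of one furan for the other leaves the number within the scatter. Nothing at hand bears on why the two furans read alike.

Still open, from the compounds shown here alone, is whether a phenyl group, an amine or a longer alkyl chain on this ring carbon would read like the furans. Also open, going by these compounds, is whether furan-3-yl and furan-2-yl would stay level with the tert-butyl ester of compound 2 in place of the benzyl ester.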